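A few compounds are considered here, and "the series" means these few. Any claim that something is new, unique, unknown or untested is made for them only; others in the source may bear on it.

Working notes on the series.

Compound 1 `C=C(C)[C@@H]1CC=C(Cn2cc(COc3ccc(C4NC(=O)NC(C)=C4C(C)=O)cc3)nn2)CC1` and compound 2 `C=C(C)[C@@H]1CC=C(Cn2cc(COc3cccc(C4NC(=O)NC(C)=C4C(C)=O)c3)nn2)CC1` are built from the same atoms joined differently; the difference between the two cores is not broken down here. In a functional assay on OVCAR-3 cells (Homo sapiens) for inhibition, read by sulforhodamine B assay, with a stated time of 48 h (on this read-out higher numbers stand for weaker inhibition of growth and lower numbers for stronger inhibition of growth), compound 1 gives 32700 nM. In this assay compound 2 gives 13300 nM, a lower number than compound 1, and the gap lies beyond the scatter.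

Compound 3 `C=C(C)[C@@H]1CC=C(Cn2cc(COc3cc(C4NC(=O)NC(C)=C4C(C)=O)ccc3OC)nn2)CC1` arises from compound 2 by a single change, (methoxy in place of hydrogen on an aromatic carbon). For compound 3 this assay reports only a limit, > 100000 nM. The step of an at least 7.5-fold higher number from compound 2 to compound 3 (0.87 log units; beyond the scatter) is therefore known only as a lower bound, because the limit of > 100000 nM in this assay, at which 1 of the 3 values shown sits, caps what can be read.

Compound 4 `C=C(C)[C@@H]1CC=C(Cn2cc(COc3ccc(C4NC(=O)NC(C)=C4C(C)=O)cc3OC)nn2)CC1` arises from compound 1 by the same kind of change, (methoxy in place of hydrogen on an aromatic carbon). Around the place the settings are not identical: in compound 4 the methoxy sits ortho to a large group and meta to a large group, whereas in compound 3 it sits ortho to a large group and para to a large group. So the two steps are of the same kind, not the same.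

Compound 1 already sits at a high number in this assay, and a step of the size seen from compound 2 to compound 3 would carry compound 4 past the cap. For compound 4 the expected value in this assay is 150000 nM, with a range from 50000 nM to 500000 nM. That expectation for compound 4 corresponds to a step of a 4.6-fold higher number from compound 1 to compound 4 (0.66 log units; beyond the scatter), and a limit rather than a number is the more probable outcome for compound 4.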

Compound 4, concentration for total growth inhibition: 48000 nM
The estimate for compound 4 lay 3.1-fold (0.49 log units) above the measured number; the whole stated range lies above it.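

Methoxy in place of hydrogen on an aromatic carbon gives, in this assay, a 1.5-fold higher number from compound 1 to compound 4 (0.17 log units; within the scatter), so on the core of compound 1 the change has no effect that can be read apart from the scatter. The change therefore does not carry from one core to the other at one size, and the step on one core cannot be taken as a forecast of the step on the other: the same change on two cores in this assay, an at least 7.5-fold higher number (0.87 log units; beyond the scatter) from compound 2 to compound 3 and a 1.5-fold higher number (0.17 log units; within the scatter) from compound 1 to compound 4, at least 5.1-fold (0.70 log units) apart, beyond the scatter of two such steps

What this does not show is the true size of the gap between the two steps, its cause, or any rule for a further core, and compound 3 stands at a limit, not a number: the limit of > 100000 nM in this assay, at which 1 of the 4 values shown sits.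

Open, going by these compounds, is whether the gap follows the place of the methoxy on the aromatic ring or some other difference between the two cores, as two pairs cannot separate these. Also open, on these data alone, is how a smaller or differently built group, such as fluorine, hydroxyl or ethoxy, would read at the same aromatic carbon on each core, and whether any of these would give a step beyond the scatter on the core of compound 1.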